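This account rests on a few compounds, and the source may have more. Where it says the series, first, only, none or still open, it means among the compounds named here.

Compound 1 `O=c1oc2ccccc2c(N2CCN(c3ccccc3)CC2)c1CO`: 17300 nM
Compound 2 `O=c1oc2ccccc2c(N2CCN(c3ccccc3F)CC2)c1CO`: 32100 nM
Compound 3 `COc1ccccc1N1CCN(c2c(CO)c(=O)oc3ccccc23)CC1`: 20000 nM

Of the compounds shown here, three sharing one core have been tested in a functional assay on A-375 cells (Homo sapiens) for inhibition, read by MTT assay, with a stated time of 24 h; a higher number here means a weaker inhibitor, a lower number a stronger inhibitor. Compound 1 gives 17300 nM, the lowest of the three numbers, though its neighbours sit close: a 1.9-fold higher number from compound 1 to compound 2 (0.27 log units; within the scatter) and a 1.2-fold higher number from compound 1 to compound 3 (0.06 log units; within the scatter), both within the scatter. Compound 2 gives 32100 nM and compound 3 gives 20000 nM, and a 1.6-fold lower number from compound 2 to compound 3 (0.21 log units; within the scatter), again within the scatter. Nothing among these three separates one from another.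

The unmeasured compound 4 `O=c1oc2ccccc2c(N2CCN(c3cccc(Cl)c3)CC2)c1CO` differs from compound 1 in one place: chloro in place of hydrogen on an aromatic carbon. The two measured steps from compound 1, adding fluoro or methoxy to the phenyl ring, bear on this change most closely, and both stayed within the scatter. Going by the values given here, a chloro at a different spot on that ring has no direct precedent here, so the expectation is simply that the number stays near that of compound 1. Compound 4 is therefore expected to give about 18000 nM, with a range from 8000 nM to 45000 nM, meaning an expected step of a 1.0-fold higher number from compound 1 to compound 4 (0.02 log units; within the scatter), not beyond the scatter.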

Compound 4, half-maximal inhibitory concentration: 40500 nM
For compound 4 the middle estimate is 2.3-fold (0.35 log units) below the measured one; low and high end bracket the measured number.
By their numbers in this assay, from the lowest: compounds 1, 3, 2 and 4 (each within the scatter of the next, the first and the last beyond it).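

In this assay, going by these compounds alone, the step (from a 2.3-fold higher number from compound 1 to compound 4 (0.37 log units; beyond the scatter)) is not how it reads best, so put plainly: a 2.3-fold higher number from compound 1 to compound 4 (0.37 log units; beyond the scatter) is the first step in this small series to lie beyond the scatter, which shows that a single added group on the phenyl ring can shift the number, though only modestly. The 3-chlorophenyl group also stands apart from the 2-methoxyphenyl group (a 2.0-fold higher number from compound 3 to compound 4 (0.31 log units; beyond the scatter)) but cannot be told apart from the 2-fluorophenyl group (a 1.3-fold higher number from compound 2 to compound 4 (0.10 log units; within the scatter)), so the chloro compound separates from compounds 1 and 3 and not from compound 2. No measured information on the compounds explains this shift.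

The compounds shown leave open whether chloro on another carbon of the ring would give the same step as it does here. They also leave open what a bromo, an amine or a carboxylic acid would do on this ring.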